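Furan-2-yl to 4-Chlorophenyl: Expecting Compound 4

The source may report more compounds than this note shows. Statements on the series, on what has been measured and on what is new or still open speak of the compounds shown alone.

Compound 1 `N#C/C(=C\c1ccc(Cl)cc1)C(=O)c1ccc[nH]1`: 34000 nM
Compound 2 `N#C/C(=C\c1c(F)c(F)c(F)c(F)c1F)C(=O)c1ccc[nH]1`: 14000 nM
Compound 3 `COc1ccc(CNC(=O)/C(C#N)=C/c2ccco2)cc1`: 24000 nM

Of the compounds shown here, three have been measured in a functional assay on BE(2)-C cells (Homo sapiens) for inhibition, read by MTT assay, with a stated time of 72 h; on this read-out lower numbers stand for stronger inhibition of growth and higher numbers for weaker inhibition of growth. Compound 3 stands second highest of the three numbers; its nearest neighbour is compound 1, and its furthest is compound 2, yet both of those gaps lie within the scatter, so no order among the three can be read. Compound 4 `COc1ccc(CNC(=O)/C(C#N)=C/c2ccc(Cl)cc2)cc1` differs from compound 3 in one place: 4-chlorophenyl in place of furan-2-yl on a double-bonded chain carbon bound to a double-bonded chain carbon. For the measured compounds named here, no step between measured compounds involving this change is available. Compound 1 carries a 4-chlorophenyl group on its own core and gives 34000 nM, a number within the scatter of compound 3; this offers no sign that the change moves the read-out far. The step from compound 3 to compound 4 in this assay is therefore expected to be small, with no direction beyond the scatter. Compound 4 is estimated at 25000 nM, within 8000 nM to 70000 nM, an expected step of a 1.0-fold higher number from compound 3 to compound 4 (0.02 log units; within the scatter).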

Compound 4, concentration for 50% growth inhibition: 12000 nM
Estimate against measurement, compound 4: 2.1-fold (0.32 log units) above, and the stated range covers the measured number.
By their numbers in this assay, from the lowest: compounds 4, 2, 3 and 1 (each within the scatter of the next, the first and the last beyond it).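

For the compounds shown here, this is the first direct step for this change: in this assay, putting 4-chlorophenyl in place of furan-2-yl on a double-bonded chain carbon bound to a double-bonded chain carbon gives a 2.0-fold lower number from compound 3 to compound 4 (0.30 log units; within the scatter) and stays within the scatter. On the core shared by compound 3 and compound 4, the five-membered oxygen-containing aromatic ring and the six-membered chlorine-bearing aromatic ring therefore cannot be told apart at this position by this read-out. No measurement is available to explain this result.

It remains open whether the same change would read alike on the core of compound 1, whose furan-2-yl counterpart is not among the compounds shown. Also open, on these data alone, is how a carboxylic acid or an amine would read in place of 4-chlorophenyl at this position.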